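This account rests on a few compounds, and the source may have more. Where it says the series, first, only, none or still open, it means among the compounds named here.

Measured compounds:
compound 1 `CC(O)(CSc1ccc(S(F)(F)(F)(F)F)cc1)C(=O)Nc1ccc(C#N)cc1C(F)(F)F`, giving 17700 nM
compound 2 `CC(O)(CSc1ccc(S(F)(F)(F)(F)F)cc1)C(=O)Nc1ccc([N+](=O)[O-])cc1C(F)(F)F`, giving 14500 nM
compound 3 `CC(O)(COc1cccc(S(F)(F)(F)(F)F)c1)C(=O)Nc1ccc(C#N)cc1C(F)(F)F`, giving 16300 nM

All three were tested in a functional assay on DU-145 cells (Homo sapiens) for antiproliferative activity, read by propidium iodide staining, with a stated time of 96 h; a higher number here means a weaker inhibitor, a lower number a stronger inhibitor. From compound 1 to compound 2 the change nitro in place of cyano on an aromatic carbon made the step of a 1.2-fold lower number from compound 1 to compound 2 (0.09 log units; within the scatter). The difference between the core of compound 1 and the core of compound 3 is not broken down here; the values of compound 1 and compound 3 lie within the usual scatter of each other, so neither can be called the stronger.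

Compound 4 `CC(O)(COc1cccc(S(F)(F)(F)(F)F)c1)C(=O)Nc1ccc([N+](=O)[O-])cc1C(F)(F)F` has not yet been measured. It relates to compound 3 by nitro in place of cyano on an aromatic carbon, the same change that led from compound 1 to compound 2. Because that earlier change gave a 1.2-fold lower number from compound 1 to compound 2 (0.09 log units; within the scatter), the step of a 1.2-fold lower number from compound 3 to compound 4 (0.08 log units; within the scatter) is expected in this assay. Compound 4 is therefore estimated at 13500 nM, expected to fall between 7000 nM and 28000 nM.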

Compound 4, half-maximal inhibitory concentration: 18000 nM
Compound 4: middle estimate off by 1.3-fold (0.12 log units), on the low side, and the stated range covers the measured number.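

In this assay, putting nitro in place of cyano on the second core gave a 1.1-fold higher number from compound 3 to compound 4 (0.04 log units; within the scatter). Set beside the earlier step, the two results do not differ: the same change on two cores in this assay, a 1.2-fold lower number (0.09 log units; within the scatter) from compound 1 to compound 2 and a 1.1-fold higher number (0.04 log units; within the scatter) from compound 3 to compound 4, 1.3-fold (0.13 log units) apart, within the scatter of two such steps. This shows that on both cores the exchange left the number within the scatter, but it does not establish a direction or a real effect of the change, and two pairs cannot show how it would behave on further cores.

The compounds shown leave open whether an amine, a carboxylic acid or a chlorine atom at that place on the ring would shift the number beyond the scatter. As far as these compounds go, whether the step holds in any other cell line also remains open.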